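The source may hold more compounds than are shown below. What is called first, only, known or untested is meant among the compounds shown, and "the series" means these compounds.

Compound 2, `O=S(=O)(c1cc(F)cc(F)c1)c1cnc2c(F)cccc2c1-c1cccc(Cl)c1`, sits second highest of the three numbers recorded in an ADME assay on microsomes from liver (Homo sapiens) for metabolic stability, tested at 2.5 uM (a lower number here means slower removal, a higher number faster removal of the compound), where compound 2 gives 0.64 mL/min. Its nearest neighbour on that scale is compound 1, `O=S(=O)(c1ccc(F)c(Cl)c1)c1cnc2c(F)cccc2c1-c1cccc(Cl)c1`, which in this assay gives 0.18 mL/min; the furthest is compound 3, `COc1ccc(-c2c(S(=O)(=O)c3cc(F)cc(F)c3)cnc3c(F)cccc23)cc1`, which gives 2.59 mL/min. The two measured steps are both modest but beyond the scatter. The step of a 3.6-fold higher number from compound 1 to compound 2 (0.55 log units; beyond the scatter) is the one in which the aryl group on the sulfonyl sulfur changes, and the step of a 4.0-fold higher number from compound 2 to compound 3 (0.61 log units; beyond the scatter) is the one in which the aryl group on an aromatic carbon of the core changes.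

The next compound, compound 4, `O=S(=O)(c1cc(Cl)cc(Cl)c1)c1cnc2c(F)cccc2c1-c1cccc(Cl)c1`, differs from compound 2 at the sulfonyl sulfur: 3,5-dichlorophenyl in place of 3,5-difluorophenyl on a sulfonyl sulfur. Within the data shown here, only the step from compound 1 to compound 2 bears on this change, since it too alters the group on the sulfonyl sulfur, and there the compound carrying a chlorine on that ring gave the lower number. With a single precedent of that size, the expectation is for a modest downward step, estimated as a 1.8-fold lower number from compound 2 to compound 4 (0.26 log units; within the scatter), although a result within the scatter would not surprise. The estimate for compound 4 in this assay is therefore 0.35 mL/min, expected to fall between 0.15 mL/min and 0.9 mL/min.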

Compound 4, intrinsic clearance in a liver preparation (reported as CLH), per the amount of preparation that the assay uses: 1.2 mL/min
Beside the measured number, compound 4's estimate is 3.4-fold (0.54 log units) below it; measured number outside the range, above it.
By their numbers in this assay, from the lowest: compound 1; then compounds 2 and 4 (each within the scatter of the next); then compound 3.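

In this assay, replacing 3,5-difluorophenyl with 3,5-dichlorophenyl on the sulfonyl sulfur gives a 1.9-fold higher number from compound 2 to compound 4 (0.27 log units; within the scatter), so these two groups cannot be told apart at this position. Chlorine on this ring therefore does not by itself go with a low number, as compound 4 carries the 3,5-dichlorophenyl group and still shows a 6.7-fold higher number from compound 1 to compound 4 (0.82 log units; beyond the scatter). Among the three groups seen on the sulfonyl sulfur, the low number belongs only to the 3-chloro-4-fluorophenyl group of compound 1, which also stands apart from the 3,5-difluorophenyl group through a 3.6-fold higher number from compound 1 to compound 2 (0.55 log units; beyond the scatter). No measurement here accounts for that difference.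

The compounds shown leave open whether this separation would persist with the 4-methoxyphenyl group of compound 3 in place of the 3-chlorophenyl group on the core, since that group appears here only with 3,5-difluorophenyl on the sulfonyl sulfur. They also leave open how this position would respond to a ring bearing a nitrile, an amine or a carboxylic acid, as every ring on the sulfonyl sulfur shown here carries only halogens.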